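Expecting a number for compound 3

The source may report more compounds than this note shows. Statements on the series, on what has been measured and on what is new or still open speak of the compounds shown alone.

Measured in a physicochemical assay for solubility, in phosphate buffer, measured as kinetic solubility, with a stated time of 24 h, at pH 6.5; a higher number here means a more soluble compound, a lower number a less soluble compound:
compound 1 `CC(C)Oc1cc(Oc2ccc(S(C)(=O)=O)cc2)cc(-c2cccc(=O)[nH]2)c1`: 11000 nM
compound 2 `Cc1cc(=O)[nH]c(-c2cc(Oc3ccc(S(C)(=O)=O)cc3)cc(OC(C)C)c2)n1`: 15000 nM

Within the data shown here, compound 1 sits within the usual scatter of the only other measured compound, so the two cannot be ranked. Compound 3 `CC(C)Oc1cc(Oc2ccc(S(C)(=O)=O)cc2)cc(-c2ncc(Cl)c(=O)[nH]2)c1`, not yet measured, differs from compound 1 in one place: a group of 8 heavy atoms (4 carbon, 2 nitrogen, 1 oxygen, 1 chlorine; one six-membered aromatic ring with 2 hetero atoms) in place of a group of 7 heavy atoms (5 carbon, 1 nitrogen, 1 oxygen; one six-membered aromatic ring with 1 hetero atom), on an aromatic carbon. That place is meta to an isopropoxy group. Among the measured compounds shown here, the one measured step that bears on this also brought in a six-membered aromatic ring with 2 hetero atoms, and it gave a 1.4-fold higher number from compound 1 to compound 2 (0.13 log units; within the scatter). For the measured compounds named here, the chlorine of compound 3 has no measured counterpart, so the range stays wide. No change beyond the scatter is therefore expected in this assay, in either direction. The expected step is a 1.1-fold lower number from compound 1 to compound 3 (0.04 log units; within the scatter). For compound 3 the estimated value is 10000 nM, with an expected range from 4000 nM to 25000 nM.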

Compound 3, solubility: 24000 nM
Compound 3: the middle estimate sits 2.4-fold (0.38 log units) below what was measured; the measured number falls inside the stated range.
By their numbers in this assay, from the lowest: compounds 1, 2 and 3 (each within the scatter of the next, the first and the last beyond it).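

In this assay, the group on the aromatic carbon meta to an isopropoxy group can shift the number beyond the scatter, though only modestly: replacing the group of compound 1 with the chlorine-bearing group gives a 2.2-fold higher number from compound 1 to compound 3 (0.34 log units; beyond the scatter). The step between the two groups that have a six-membered aromatic ring with 2 hetero atoms, a 1.6-fold higher number from compound 2 to compound 3 (0.20 log units; within the scatter), stays within the scatter, so those two compounds cannot be ranked. Nothing at hand explains why the number rises.

The compounds shown do not separate the contribution of the chlorine from that of the second hetero atom in the ring, since the step beyond the scatter brings in both at once. Also open, going by these compounds, is how a group such as an amine or a carboxylic acid at this place would read in this assay.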